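Swapping the chlorophenyl of compound 3 for methoxyphenyl

A few compounds are considered here, and "the series" means these few. Any claim that something is new, unique, unknown or untested is made for them only; others in the source may bear on it.

Compound 3 `O=S(=O)(NCCCNCc1cccc(Cl)c1)c1cc(C(F)(F)F)cc(C(F)(F)F)c1` gives 3800 nM in a functional assay on BXPC-3 cells (Homo sapiens) for inhibition, read by MTT assay, with a stated time of 72 h (on this read-out lower numbers stand for stronger inhibition of growth and higher numbers for weaker inhibition of growth), the highest of the three numbers. Compound 1 `CC(C)(C)c1ccc(CNCCCNS(=O)(=O)c2cc(C(F)(F)F)cc(C(F)(F)F)c2)cc1` gives 1400 nM and compound 2 `O=S(=O)(NCCCCNCc1ccc(Br)cc1)c1cc(C(F)(F)F)cc(C(F)(F)F)c1` gives 1700 nM. The step of a 2.7-fold higher number from compound 1 to compound 3 (0.43 log units; beyond the scatter) and the step of a 2.2-fold higher number from compound 2 to compound 3 (0.35 log units; beyond the scatter) both run into compound 3 by a modest margin. Compound 4 `COc1ccccc1CNCCCNS(=O)(=O)c1cc(C(F)(F)F)cc(C(F)(F)F)c1` differs from compound 3 by 2-methoxyphenyl in place of 3-chlorophenyl on a saturated chain carbon bound to an amine nitrogen. Going by the values given here, no measured step covers this exact change; the two steps into compound 3 only show that swapping the aryl group at this position moves this assay by modest amounts. For compound 4 a step of about a 1.1-fold higher number from compound 3 to compound 4 (0.02 log units; within the scatter) is therefore expected, with no firm direction. Compound 4 is estimated at 4000 nM, in a range from 1500 nM to 11000 nM.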

Compound 4, concentration for 50% growth inhibition: 1700 nM
For compound 4 the middle estimate is 2.4-fold (0.37 log units) above the measured one, within the range that was stated.
By their numbers in this assay, from the lowest: compounds 1, 2 and 4 (each within the scatter of the next); then compound 3.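

In this assay the change to 2-methoxyphenyl on a saturated chain carbon bound to an amine nitrogen gives a 2.2-fold lower number from compound 3 to compound 4 (0.35 log units; beyond the scatter) and shows that a group carrying a hydrogen-bond acceptor is tolerated here. The remaining steps, a 1.2-fold higher number from compound 1 to compound 4 (0.08 log units; within the scatter) and no change at the digits printed from compound 2 to compound 4 (within the scatter), lie within the scatter, leaving compound 3 alone apart from the other three. Nothing measured here accounts for the shift.

Still open, going by these compounds, is whether 2-chlorophenyl or 3-methoxyphenyl would read like compound 3 or like compound 4, which would separate the effect of the group from that of where it sits.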